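The compounds below may be only part of what the source reports. "The series", "measured", "known", "first", "only" and "open" are said of these compounds alone.

Compound 3 `COC(=O)C1=C(C)N=C(C)/C(=C(\O)OC)C1c1cccc(C#N)c1` gives 34.7 nM in a functional assay (muscle tissue) with Cavia porcellus as the target (on this read-out lower numbers stand for an effect already at smaller amounts and higher numbers for an effect only at larger amounts of compound), the second highest of the three numbers seen so far; compound 1 `COC(=O)C1=C(C)N=C(C)/C(=C(\O)OC)C1c1ccccc1Cl` gives 2.19 nM and compound 2 `COC(=O)C1=C(C)N=C(C)/C(=C(\O)OC)C1c1ccc(I)cc1` gives 22900 nM. The steps of a 16-fold higher number from compound 1 to compound 3 (1.20 log units; beyond the scatter) and a 10000-fold higher number from compound 1 to compound 2 (4.02 log units; beyond the scatter) both show the 2-chlorophenyl compound well ahead, and a 660-fold lower number from compound 2 to compound 3 (2.82 log units; beyond the scatter) places the 3-cyanophenyl compound between the two. Compound 4 `COC(=O)C1=C(C)N=C(C)/C(=C(\O)OC)C1c1ccccc1OC` brings (2-methoxyphenyl in place of 3-cyanophenyl on a saturated ring carbon). The entering 2-methoxyphenyl is closer in kind to the 2-chlorophenyl of compound 1 than to the groups of compound 2 or compound 3, so the step of a 6.9-fold lower number from compound 3 to compound 4 (0.84 log units; beyond the scatter) in this assay is expected to run toward a lower number, largely reversing the move seen from compound 1. Compound 4 is therefore estimated at 5 nM, with a range of 1 nM to 40 nM.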

Compound 4, half-maximal effective concentration: 57.5 nM
Compound 4: the middle estimate sits 12-fold (1.06 log units) below what was measured, outside the stated range (above it).
By their numbers in this assay, from the lowest: compound 1; then compounds 3 and 4 (each within the scatter of the next); then compound 2.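

In this assay methoxy in place of chloro on the same aromatic carbon is a large step (a 26-fold higher number from compound 1 to compound 4 (1.42 log units; beyond the scatter)), so sharing that ring place does not by itself carry over the low number of compound 1. The 2-methoxyphenyl and 3-cyanophenyl groups cannot be told apart here (a 1.7-fold higher number from compound 3 to compound 4 (0.22 log units; within the scatter)), while the 4-iodophenyl group remains far off (a 400-fold lower number from compound 2 to compound 4 (2.60 log units; beyond the scatter)). Nothing shown accounts for these steps.

Open, from the compounds shown here alone, is whether fluoro, methyl or trifluoromethyl on that aromatic carbon would stay near compound 1. Also open, going by these compounds, is whether the gap at compound 2 belongs to iodo itself or to its place on the ring.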